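Methyl in place of methoxy on the anilino ring

The source may report more compounds than this note shows. Statements on the series, on what has been measured and on what is new or still open speak of the compounds shown alone.

Measured so far:
compound 1, `COc1ccc(NC2=CC(=O)c3c(nc4n3[C@H]3OC[C@@H](O)[C@H]3OC4)C2=O)cc1`: > 8000 nM
compound 2, `O=C1C=C(Nc2ccccc2)C(=O)c2c1nc1n2[C@H]2OC[C@@H](O)[C@H]2OC1`: 5620 nM
compound 3, `O=C1C=C(Nc2ccc(C(F)(F)F)cc2)C(=O)c2c1nc1n2[C@H]2OC[C@@H](O)[C@H]2OC1`: > 8000 nM

In a functional assay on HeLa cells (Homo sapiens) for inhibition, read by sulforhodamine B assay (a lower number here means a stronger inhibitor, a higher number a weaker inhibitor), compound 1 gives > 8000 nM, which is a limit of the assay and not a number. Among the compounds with values here, compound 2 gives 5620 nM in this assay, the only numerical value in the set. Compound 3 gives > 8000 nM, again a limit. Compound 1 thus stands at the weak end of what has been measured, and the limit of > 8000 nM in this assay, at which 2 of the 3 values shown sit, is where two of the three values sit.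

Compound 4 is `Cc1ccc(NC2=CC(=O)c3c(nc4n3[C@H]3OC[C@@H](O)[C@H]3OC4)C2=O)cc1`. The change from compound 1: methyl in place of methoxy on an aromatic carbon. Within the data shown here, no measured step swaps methoxy for methyl. Among the measured compounds shown here, the only measured step, an at least 1.4-fold higher number from compound 2 to compound 3 (0.15 log units; that floor lies within the scatter), shows a group entering on the aromatic carbon in place of hydrogen giving a number at the limit rather than a stronger inhibitor. Both substituted compounds, compound 1 and compound 3, sit at the limit, while unsubstituted compound 2 gives a number. Since compound 1 is known only as a limit, the step to compound 4 cannot be sized from the data; the expectation is no step beyond the scatter, a step that the limit leaves unreadable from compound 1 to compound 4, with a substantial chance that compound 4 again reports only a limit. Compound 4 is therefore estimated at 9000 nM, within the range 4000 nM to 20000 nM.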

Compound 4, half-maximal inhibitory concentration: 6590 nM
Beside the measured number, compound 4's estimate is 1.4-fold (0.14 log units) above it; the measured number falls inside the stated range.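

In this assay, methyl in place of methoxy on the anilino ring gives an at least 1.2-fold lower number from compound 1 to compound 4 (0.08 log units; that floor lies within the scatter), so only a floor on this change can be read, and that floor does not separate the two groups. Compound 4 is the first compound shown to carry a group on the aromatic carbon para to a large group and still return a number, so the two earlier substituted compounds do not make a rule that any group at this position ends at the limit. Compound 2, with hydrogen at the same carbon, gives 5620 nM, and compound 4 gives 6590 nM, so the methyl compound and the unsubstituted compound both remain weak inhibitors in the micromolar range.

As far as these compounds go, the true values of compound 1 and compound 3 remain unknown, and no trend across the substituents can be drawn from them: the limit of > 8000 nM in this assay, at which 2 of the 4 values shown sit. Also open is how this position responds to an amine, a carboxylic acid or a longer alkyl chain in place of methyl, and whether any such group moves the number beyond the scatter.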